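A Thioanisyl Ether Gives Way to a Fluorobenzyl Group

A few compounds are considered here, and "the series" means these few. Any claim that something is new, unique, unknown or untested is made for them only; others in the source may bear on it.

Measured compounds:
- compound 1 `COc1ccc(OC(C)(C)C2OCC(C/C=C\CCC(=O)O)C(c3cccnc3)O2)cc1`: 41 nM
- compound 2 `CSc1ccccc1OC(C)(C)C1OCC(C/C=C\CCC(=O)O)C(c2cccnc2)O1`: 36 nM
- compound 3 `COc1ccc(OC(C)(C)C2OCC(C/C=C\CCC(=O)O)C(c3cccnc3)O2)c([N+](=O)[O-])c1`: 37 nM

In an assay for inhibition of Thromboxane-A synthase (Homo sapiens), using microsomes (on this read-out lower numbers stand for stronger inhibition and higher numbers for weaker inhibition), compound 2 gives 36 nM, the lowest of the three numbers, though its neighbours sit within the scatter: the step of a 1.1-fold lower number from compound 1 to compound 2 (0.06 log units; within the scatter) and the step of a 1.0-fold higher number from compound 2 to compound 3 (0.01 log units; within the scatter) are both small, as is the step of a 1.1-fold lower number from compound 1 to compound 3 (0.04 log units; within the scatter). The three compounds therefore cannot be ranked against one another.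

Compound 4 `CC(C)(Cc1ccc(F)cc1)C1OCC(C/C=C\CCC(=O)O)C(c2cccnc2)O1` has not yet been tested. It differs from compound 2 as follows: 4-fluorobenzyl in place of 2-(methylsulfanyl)phenoxy on a saturated chain carbon bound to two saturated chain carbons and a saturated ring carbon. Going by the values given here, no measured step touches this kind of change. The three known steps only vary the substituents on the aryl ring that hangs from the oxygen, and all three stay within the scatter, which suggests the aryl portion tolerates variation. Here, however, the oxygen itself is removed and the aryl ring is shifted out by one carbon, so the outcome is less certain.

Compound 4 is therefore expected to give about 55 nM in this assay, with a plausible range from 15 nM to 200 nM, which would mean a step of a 1.5-fold higher number from compound 2 to compound 4 (0.18 log units; within the scatter) from compound 2, a change that may well remain within the scatter.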

Compound 4, half-maximal inhibitory concentration: 45 nM
Compound 4: the middle estimate sits 1.2-fold (0.09 log units) above what was measured; the measured number falls inside the stated range.
By their numbers in this assay, from the lowest: compounds 2, 3, 1 and 4 (each within the scatter of the next).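

In this assay, the change at the saturated chain carbon bound to two saturated chain carbons and a saturated ring carbon goes beyond ring decoration, and both steps that record it, a 1.3-fold higher number from compound 2 to compound 4 (0.10 log units; within the scatter) and a 1.1-fold higher number from compound 1 to compound 4 (0.04 log units; within the scatter), stay within the scatter. The earlier compounds shown here all kept the oxygen and varied only the substituents on the aryl ring, whereas these two steps show that 4-fluorobenzyl can take the place of either 2-(methylsulfanyl)phenoxy or 4-methoxyphenoxy, with the oxygen gone, and the step still does not leave the scatter. No measurement shown here accounts for this outcome.

The compounds shown leave open whether an aryl ring is needed at this carbon at all, and whether an amine or a plain longer alkyl chain in the same place would also stay within the scatter of compound 2. They also leave open how far this tolerance reaches beyond the aryl portion, for instance if the carboxylic acid on the shared core were replaced by an amide.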